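Swapping the sulfur group of compound 1

This account rests on a few compounds, and the source may have more. Where it says the series, first, only, none or still open, it means among the compounds named here.

Measured so far in an ADME assay on microsomes from liver (Mus musculus, strain CD-1) for metabolic stability, read by LC-MS, with a stated time of 60 min, tested at 20 uM (a lower number here means that the compound disappears faster, a higher number that the compound lasts longer), for three compounds:
Compound 1 `O=c1c2cn(C3COC3)nc2nc(SCc2cccc(F)c2)n1-c1ccccc1` gives 0.383 h
Compound 2 `COc1cccc(C(C)Sc2nc3c(cnn3C)c(=O)n2-c2ccccc2)c1` gives 0.1 h
Compound 3 `CC(Sc1nc2c(cnn2C)c(=O)n1-c1ccccc1)c1cccnc1` gives 0.117 h

Compound 1 stands highest of the three, beyond the scatter of both compound 2 and compound 3. Compound 4 `CC(Sc1nc2nn(C3COC3)cc2c(=O)n1-c1ccccc1)c1cccnc1` has not been measured yet. It keeps the core of compound 1, but 1-(pyridin-3-yl)ethyl comes in place of 3-fluorobenzyl on a sulfur (1-(pyridin-3-yl)ethyl in place of 3-fluorobenzyl on a sulfur), so a six-membered aromatic ring of carbon only gives way to one with 1 hetero atom.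

For the measured compounds named here, only one measured step bears on this, and only partly. Putting pyridin-3-yl in place of 3-methoxyphenyl gave a 1.2-fold higher number from compound 2 to compound 3 (0.07 log units; within the scatter) and so shows no large shift from a ring swap alone. Going by the values given here, that step sits on a different core, and no measured step removes 3-fluorobenzyl itself. Compound 3 carries the entering group and gives only 0.117 h on its own core, which suggests a slight lean downward, although the data cannot separate the sulfur group from the rest of the molecule. The expected change is therefore small and downward in this assay, with an estimated step of a 1.5-fold lower number from compound 1 to compound 4 (0.19 log units; within the scatter) as the working guess. For compound 4 the estimate is 0.25 h as the expected value, with 0.1 h to 0.55 h as its likely range.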

Compound 4, half-life in the Mus musculus assay: 0.045 h
Estimate against measurement, compound 4: 5.6-fold (0.74 log units) above, outside the stated range (below it).
By their numbers in the Mus musculus assay, from the lowest: compound 4; then compounds 2 and 3 (each within the scatter of the next); then compound 1.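

On the core of compound 1, the group on the sulfur has a strong hold on the number in the Mus musculus assay: 1-(pyridin-3-yl)ethyl in place of 3-fluorobenzyl gives an 8.5-fold lower number from compound 1 to compound 4 (0.93 log units; beyond the scatter). The earlier ring swap on the other core, a 1.2-fold higher number from compound 2 to compound 3 (0.07 log units; within the scatter), showed no such movement, so the small step there did not foretell the large one here. The same change moves the two read-outs in opposite directions, with the number rising in a physicochemical assay for solubility, using the shake flask method, in phosphate buffer, with a stated time of 24 h, at pH 7.4 (on this read-out higher numbers stand for higher solubility and lower numbers for lower solubility), from compound 1 at 5000 nM to compound 4 at 189000 nM, so the longer-lasting compound of this pair is the less soluble one: the measured solubility of compound 1, 5000 nM, and of compound 4, 189000 nM, a 38-fold higher number (1.58 log units; beyond the scatter).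

Only this one pair carries the change on this core, and it replaces the ring and the chain together, so the compounds shown cannot tell whether the ring nitrogen, the loss of fluorine or the branched ethyl chain lies behind either shift. Groups such as pyridin-3-ylmethyl or 1-(3-fluorophenyl)ethyl on the sulfur would pull those parts apart, and how an amine or a carboxylic acid in that place would fare on both read-outs remains open.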